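A few compounds are considered here, and "the series" means these few. Any claim that something is new, unique, unknown or untested is made for them only; others in the source may bear on it.

In a physicochemical assay for lipophilicity, read by HPLC, at pH 7.5 (a lower number here means a more polar compound, a higher number a more lipophilic compound), compound 2 (`CC[C@@H](Nc1c(C#N)c(-c2ccc(-c3ccccc3CO)cc2)nc2cnccc12)C(N)=O`) stands at 2.1 and compound 1 (`CC[C@@H](Nc1c(C#N)c(-c2ccc(Br)cc2)nc2cnccc12)C(N)=O`) at 2.2 with the two lying within the usual scatter of each other. For the measured compounds named here, only one measured step is available as a guide. It replaces bromo on an aromatic carbon with 2-(hydroxymethyl)phenyl and comes out as a number 0.10 log units lower from compound 1 to compound 2 (within the scatter) on this scale. Compound 3 (`CC[C@@H](Nc1c(C#N)c(-c2ccc(-c3ccccc3OC)cc2)nc2cnccc12)C(N)=O`) has the same atoms as compound 2, joined differently (methoxy in place of hydroxymethyl on an aromatic carbon) with methoxy in place of hydroxymethyl on an aromatic carbon. Neither compound in the measured step carries a methoxy, so that small step is only a weak guide, and the expectation rests mainly on the structural change itself. A modest upward move is expected, and the estimated step is a number 0.40 log units higher from compound 2 to compound 3 (beyond the scatter) on this scale. Compound 3 is expected to read 2.5 in this assay with an estimated range from 2.1 to 2.9 around that figure.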

Compound 3, distribution coefficient: 2.7
The estimate for compound 3 lay 0.20 log units below the measured number, within the range that was stated.
By their numbers in this assay, from the lowest: compounds 2 and 1 (each within the scatter of the next); then compound 3.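

Read by this assay the change from hydroxymethyl to methoxy on this aromatic carbon, ortho to a large group, gives a number 0.60 log units higher from compound 2 to compound 3 (beyond the scatter) even though the two groups have the same atoms, joined differently. This place therefore responds to how those atoms are joined, something compounds 1 and 2 could not show, as they lie within the scatter of each other. Against bromo, 2-methoxyphenyl gives a number 0.50 log units higher from compound 1 to compound 3 (beyond the scatter) so the reading depends on what the added ring carries, here methoxy with 0 hydrogen-bond donors rather than hydroxymethyl with 1 hydrogen-bond donor.

From the compounds shown here alone, how an amine or a carboxylic acid at this place, or a longer chain in place of methoxy, would read remains open. No measurement at hand explains the shift.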